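Pyridinyl for fluorophenyl on a benzimidazole sulfone series

The source may hold more compounds than are shown below. What is called first, only, known or untested is meant among the compounds shown, and "the series" means these compounds.

Measured so far: compound 1 `CS(=O)(=O)c1ccc2nc(-c3ccc(-c4ccc(Cl)cc4)cc3)[nH]c2c1` gives > 20000 nM in an assay on isolated protein for inhibition of acyl-CoA desaturase 1 (Rattus norvegicus) (a lower number here means a stronger inhibitor, a higher number a weaker inhibitor), and that value is a limit of the assay, not a number. Compound 2 `CS(=O)(=O)c1ccc2nc(-c3ccc(-c4cccc(F)c4)cc3)[nH]c2c1` gives 21 nM in this assay.

For the measured compounds named here, compound 2 thus holds the only numerical value shown; the other value is a limit (the limit of > 20000 nM in this assay, at which 1 of the 2 values shown sits). Compound 3 `CS(=O)(=O)c1ccc2nc(-c3ccc(-c4ccncc4)cc3)[nH]c2c1` is not yet measured. It differs from compound 2 by pyridin-4-yl in place of 3-fluorophenyl on an aromatic carbon. Going by the values given here, the one measured step, an at least 950-fold lower number from compound 1 to compound 2 (2.97 log units; beyond the scatter), touched the same ring and was large, showing that this ring tolerates little change without a big effect. Compound 3 swaps that ring for a nitrogen-containing one, so a step beyond the scatter is expected, most likely toward a higher number. For compound 3 the estimated value in this assay is 250 nM, between 30 nM and 3000 nM. This estimate means a step of a 12-fold higher number from compound 2 to compound 3 (1.08 log units; beyond the scatter) is expected.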

Compound 3, half-maximal inhibitory concentration: 2470 nM
Beside the measured number, compound 3's estimate is 9.9-fold (0.99 log units) below it; measured number inside the range.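

At this position, para to a large group, the identity of the ring decides the outcome: pyridin-4-yl in place of 3-fluorophenyl gives a 120-fold higher number from compound 2 to compound 3 (2.07 log units; beyond the scatter) in this assay. Pyridin-4-yl in place of 4-chlorophenyl still gives an at least 8.0-fold lower number from compound 1 to compound 3 (0.90 log units; beyond the scatter), so the three rings shown give three distinct levels rather than a simple split into active and inactive. The size of that second step is only a bound, because the value of compound 1 is a limit of the assay: the limit of > 20000 nM in this assay, at which 1 of the 3 values shown sits.

The compounds shown leave open whether the loss in compound 3 follows from the ring nitrogen or from the missing fluorine, a question that an unsubstituted phenyl group would separate. Also open, on these data alone, is how a pyridin-3-yl or a 3-chlorophenyl group would behave here.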